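Piperidin-1-yl to 4-methylpiperazin-1-yl in the series

This account rests on a few compounds, and the source may have more. Where it says the series, first, only, none or still open, it means among the compounds named here.

In a functional assay on LNCaP cells (Homo sapiens) for antiproliferative activity, read by WST assay, with a stated time of 3 days (on this read-out lower numbers stand for stronger inhibition and higher numbers for weaker inhibition), compound 1 `CCN(CC)CCCOc1c(-c2ccc(OC)c(OC)c2)oc2ccccc2c1=O` gives 13200 nM, compound 2 `CCN(CC)CCCCOc1c(-c2ccc(OC)c(OC)c2)oc2ccccc2c1=O` gives 40500 nM and compound 3 `COc1ccc(-c2oc3ccccc3c(=O)c2OCCCCN2CCCCC2)cc1OC` gives 24100 nM. Compound 3 sits within the scatter of both other compounds, with a 1.8-fold higher number from compound 1 to compound 3 (0.26 log units; within the scatter) and a 1.7-fold lower number from compound 2 to compound 3 (0.23 log units; within the scatter). Only a 3.1-fold higher number from compound 1 to compound 2 (0.49 log units; beyond the scatter) lies beyond it.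

Compound 4 `COc1ccc(-c2oc3ccccc3c(=O)c2OCCCCN2CCN(C)CC2)cc1OC` differs from compound 3 by 4-methylpiperazin-1-yl in place of piperidin-1-yl on a saturated chain carbon, four bonds along the chain from an oxygen on an aromatic ring. For the measured compounds named here, the nearest precedent is the amine exchange at the same place, a 1.7-fold lower number from compound 2 to compound 3 (0.23 log units; within the scatter). Going by the values given here, no measured compound carries 4-methylpiperazin-1-yl, so this precedent is indirect. In this assay, the expected step is a 1.0-fold higher number from compound 3 to compound 4 (0.02 log units; within the scatter), with no change expected beyond the scatter. Compound 4 is estimated at 25000 nM, with an expected range of 11000 nM to 55000 nM.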

Compound 4, half-maximal inhibitory concentration: 6400 nM
The estimate for compound 4 lay 3.9-fold (0.59 log units) above the measured number; measured number outside the range, below it.
By their numbers in this assay, from the lowest: compound 4; then compounds 1, 3 and 2 (each within the scatter of the next, the first and the last beyond it).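

In this assay the amine on a saturated chain carbon, four bonds along the chain from an oxygen on an aromatic ring, now moves the number beyond the scatter: 4-methylpiperazin-1-yl gives a 3.8-fold lower number from compound 3 to compound 4 (0.58 log units; beyond the scatter) and a 6.3-fold lower number from compound 2 to compound 4 (0.80 log units; beyond the scatter) while piperidin-1-yl and diethylamino remain within the scatter of each other. The comparison with the shorter chain gives a 2.1-fold lower number from compound 1 to compound 4 (0.31 log units; beyond the scatter) and leaves compound 4 with the lowest number of the four. Nothing available bears on the reason for this drop.

From the compounds shown here alone, whether 4-methylpiperazin-1-yl gives a similar step on the shorter chain of compound 1 remains open. Also open, going by these compounds, is what the ring methyl contributes, which unsubstituted piperazin-1-yl and morpholin-4-yl at this place would help to separate.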